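Bromomethyl for But-1-en-1-yl on an Anilide Carbonyl

The source may hold more compounds than are shown below. What is called first, only, known or untested is meant among the compounds shown, and "the series" means these compounds.

Measured compounds:
compound 1 `CC/C=C/C(=O)N(Cc1ccc(OC)c(O)c1)c1cc(OC)c(OC)c(OC)c1` — 63 nM
compound 2 `COc1ccc(N(Cc2cc(OC)c(OC)c(OC)c2)C(=O)CCl)cc1O` — 22500 nM

The study reads growth inhibition in a functional assay on HCT-116 cells (Homo sapiens) for inhibition, read by MTT assay, with a stated time of 48 h; a higher number here means a weaker inhibitor, a lower number a stronger inhibitor. Going by the values given here, compound 1 `CC/C=C/C(=O)N(Cc1ccc(OC)c(O)c1)c1cc(OC)c(OC)c(OC)c1` gives 63 nM, the lowest of the two numbers known. Compound 2 `COc1ccc(N(Cc2cc(OC)c(OC)c(OC)c2)C(=O)CCl)cc1O` gives 22500 nM, a far higher number, beyond the scatter; compound 2 differs from compound 1 in more than one place, so the two values alone cannot be assigned to any single change.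

Compound 3 `COc1ccc(CN(C(=O)CBr)c2cc(OC)c(OC)c(OC)c2)cc1O` is not yet measured. It keeps the core of compound 1 and differs only at the carbonyl: bromomethyl in place of but-1-en-1-yl on a carbonyl carbon

Among the compounds with values here, no measured pair isolates this change. Within the data shown here, the only other compound carrying a halogen, compound 2, gives 22500 nM, which leans toward a weaker result for compound 3, though the aryl arrangement there differs. In this assay compound 3 is therefore expected to show a loss, a 40-fold higher number from compound 1 to compound 3 (1.60 log units; beyond the scatter), with a wide uncertainty. The estimate for compound 3 is 2500 nM, within 250 nM to 20000 nM.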

Compound 3, half-maximal inhibitory concentration: 68 nM
For compound 3 the middle estimate is 37-fold (1.57 log units) above the measured one, and the stated range ends above it.
By their numbers in this assay, from the lowest: compounds 1 and 3 (each within the scatter of the next); then compound 2.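

Bromomethyl in place of but-1-en-1-yl on a carbonyl carbon gives, in this assay, a 1.1-fold higher number from compound 1 to compound 3 (0.03 log units; within the scatter), and this is the first measured pair that isolates this position. With the core of compound 1 held constant, the assay does not separate the two groups, although the entering group has fewer heavy atoms, carries a bromine and lacks the double bond outside aromatic rings. No measurement shown here explains why the two groups read alike.

The compounds shown leave open whether the bromine, the short chain or neither decides the reading at this carbonyl, since the core of compound 1 appears here with neither chloromethyl, plain methyl nor a saturated butyl chain in this place. They also leave open how an aminomethyl group or a carboxylic acid would read on this carbonyl carbon, and whether the exchange would read alike on the different aryl arrangement of compound 2.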